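Working notes: 2-iodophenyl to 2,5-dimethoxyphenyl

The source may report more compounds than this note shows. Statements on the series, on what has been measured and on what is new or still open speak of the compounds shown alone.

- Compound 1 `CC(=O)Oc1ccccc1/C=C/c1nc2ccccc2c(=O)[nH]1`: > 25000 nM (a limit)
- Compound 2 `CC(=O)Oc1ccccc1/C=C/c1nc(Nc2ccccc2I)c2ccccc2n1`: 16400 nM

Among the measured compounds shown here, in a functional assay on A549 cells (Homo sapiens) for antiproliferative activity, with a stated time of 72 h (on this read-out lower numbers stand for stronger inhibition and higher numbers for weaker inhibition), compound 2 gives 16400 nM, the only actual number so far. The entry for compound 1, > 25000 nM, is a limit and not a number.

Compound 3 `COc1ccc(OC)c(Nc2nc(/C=C/c3ccccc3OC(C)=O)nc3ccccc23)c1` has 2,5-dimethoxyphenyl in place of 2-iodophenyl on a nitrogen on an aromatic ring. For the measured compounds named here, no measured pair shows this change or any other single change, so the size of the step cannot be read from the data. A modest move towards stronger inhibition in this assay is expected, and a result within the usual scatter would be no surprise. The expected change is a 1.6-fold lower number from compound 2 to compound 3 (0.21 log units; within the scatter). For compound 3 the estimated value is 10000 nM, with an expected range of 2500 nM to 25000 nM.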

Compound 3, half-maximal inhibitory concentration: > 25000 nM
Compound 3 ended at the assay's limit (the forecaster's own chance of this, stated with the estimate: 20%); middle value at least 2.5-fold (0.39 log units) from the limit.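

In this assay, among the compounds shown here, the change to 2,5-dimethoxyphenyl on this nitrogen gives the first step that can be read, an at least 1.5-fold higher number from compound 2 to compound 3 (0.18 log units; that floor lies within the scatter), so it brings no gain over 2-iodophenyl, and any loss remains unproven while the floor of the step lies within the scatter. The entry for compound 3, > 25000 nM, is a limit and not a number. The true size of the step stays unknown because the read-out ends at a limit: the limit of > 25000 nM in this assay, at which 2 of the 3 values shown sit.

For the compounds shown here, the series still has no compound at this place with a number stronger than that of compound 2, 16400 nM, so how far this position can move the read-out remains open. On these data alone, how a plain phenyl or a morpholine would read at this place is also open.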